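The compounds below may be only part of what the source reports. "The series", "measured", "known", "first", "only" and "open" are said of these compounds alone.

Compound 2 `Cc1cc(C)cc(-n2nncc2CN2C(=O)C3(C(C#N)=C(N)Oc4c(N)cc5nc6ccccc6nc5c43)c3ccccc32)c1` is known in an ADME assay on HUVEC cells (Homo sapiens) for antiproliferative activity, read by MTT assay, with a stated time of 48 h (a lower number here means a stronger inhibitor, a higher number a weaker inhibitor), only as a limit: compound 2 gives > 50000 nM, a limit of the assay rather than a number. Its neighbour compound 1 `CCc1ccccc1-n1nncc1CN1C(=O)C2(C(C#N)=C(N)Oc3c(N)cc4nc5ccccc5nc4c32)c2ccccc21` stands at a limit too. Compound 1 gives > 50000 nM. The step that the two limits leave unreadable from compound 1 to compound 2 therefore cannot be read, since the limit of > 50000 nM in this assay, at which 2 of the 2 values shown sit, holds both values. Compound 3 `N#CC1=C(N)Oc2c(N)cc3nc4ccccc4nc3c2C12C(=O)N(Cc1cnnn1-c1ccc([N+](=O)[O-])cc1[N+](=O)[O-])c1ccccc12` is the next member, differing from compound 2 by 2,4-dinitrophenyl in place of 3,5-dimethylphenyl on an aromatic nitrogen. Among the compounds with values here, the only measured step bearing on this position is the unreadable one from compound 1 to compound 2, so it offers no size or direction to carry over. With both known values sitting at the limit, the estimate for compound 3 in this assay is 60000 nM, with a range from 20000 nM to 200000 nM. The step this expectation implies from compound 2 to compound 3, a step that the limit leaves unreadable from compound 2 to compound 3, is expected to be a change that cannot be separated from scatter around the limit.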

Compound 3, half-maximal inhibitory concentration: > 50000 nM
Compound 3 ended at the assay's limit; the forecaster's own chance of this, stated with the estimate: 80%; the middle value does not contradict the limit.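

No step among compound 1, compound 2 and compound 3 can be read, because all three stand at the same limit: the limit of > 50000 nM in this assay, at which 3 of the 3 values shown sit.

The compounds shown leave open whether any group on the aromatic nitrogen can move the result away from that limit.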